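Swapping Furan for Thiophene in an Adenosine Receptor Amide

The source may hold more compounds than are shown below. What is called first, only, known or untested is meant among the compounds shown, and "the series" means these compounds.

Compound 1 `Cc1ccc(C(=O)Nc2nc(-c3ccccc3)cn3cc(-c4ccccc4)nc23)cc1`: 1%
Compound 2 `O=C(Nc1nc(-c2ccccc2)cn2cc(-c3ccccc3)nc12)c1ccco1`: 10%

In an assay on cells for displacement of a labelled ligand from adenosine receptor A1 (Homo sapiens), read by scintillation counting, with a stated time of 120 min, tested at 1 uM (on this read-out higher numbers stand for more inhibition at the one concentration tested (going by the name of the read-out) and lower numbers for less inhibition), compound 1 gives 1% and compound 2 gives 10%. Within the data shown here, compound 2 shows the larger of the two numbers, yet the only step so far, a number 9 percentage points higher from compound 1 to compound 2 (within the scatter), lies within the scatter, so the two compounds cannot be told apart. Compound 3 `O=C(Nc1nc(-c2ccccc2)cn2cc(-c3ccccc3)nc12)c1cccs1` differs from compound 2 in the same place: thiophen-2-yl in place of furan-2-yl on a carbonyl carbon. Among the measured compounds shown here, the one relevant step being within the scatter, no change beyond the scatter is expected for compound 3, so no change at the digits printed from compound 2 to compound 3 (within the scatter). Compound 3 is therefore estimated at 10%, in the range 0% to 25%.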

Compound 3, a percentage reported as inhibition, at one concentration (the size of the read-out at that concentration, not a potency): 5%
Beside the measured number, compound 3's estimate is 5 percentage points above it, within the range that was stated.
By their numbers in this assay, from the lowest: compounds 1, 3 and 2 (each within the scatter of the next).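

In this assay, thiophen-2-yl in place of furan-2-yl on the carbonyl carbon gives a number 5 percentage points lower from compound 2 to compound 3 (within the scatter) and thiophen-2-yl in place of 4-methylphenyl gives a number 4 percentage points higher from compound 1 to compound 3 (within the scatter) at this same position. Exchanging the ring oxygen for sulfur therefore makes no readable difference, and the three groups tried here cannot be told apart. Nothing available explains this result.

From the compounds shown here alone, what stays open is whether a different kind of group on this carbonyl carbon, such as an amine or a longer alkyl chain, would give a number clearly outside the scatter.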